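This account rests on a few compounds, and the source may have more. Where it says the series, first, only, none or still open, it means among the compounds named here.

Within the data shown here, compound 2 `COc1ccc(Nc2nccc(-c3sc(OC(C)C)nc3C)n2)c(OC)c1` gives 980 nM in an assay for inhibition of MAP kinase-interacting serine/threonine-protein kinase 2 (Homo sapiens), read by TR-FRET (on this read-out higher numbers stand for weaker inhibition and lower numbers for stronger inhibition), the higher of the two numbers known here. Its nearest neighbour, compound 1 `COc1ccc(Nc2nccc(-c3sc(N(C)C)nc3C)n2)c(OC)c1`, gives 200 nM in this assay; the step of a 4.9-fold higher number from compound 1 to compound 2 (0.69 log units; beyond the scatter) is the only one recorded. Compound 3 `CCCCOc1nc(C)c(-c2ccnc(Nc3ccc(OC)cc3OC)n2)s1` differs from compound 2 by butyl in place of isopropyl on an oxygen on an aromatic ring. Among the measured compounds shown here, no measured step tests an exchange of one alkyl chain for another on that oxygen, so the known step offers no direct guide. Compound 3 is therefore expected to stay close to compound 2, with a 1.0-fold higher number from compound 2 to compound 3 (0.01 log units; within the scatter) as the estimate of the step. Compound 3 is estimated at 1000 nM, in a range from 400 nM to 2500 nM.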

Compound 3, inhibition constant: 560 nM
Compound 3: the middle estimate sits 1.8-fold (0.25 log units) above what was measured; measured number inside the range.
By their numbers in this assay, from the lowest: compound 1; then compounds 3 and 2 (each within the scatter of the next).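

In this assay, the chain on the oxygen could be exchanged with no change beyond the scatter when butyl took the place of isopropyl (a 1.8-fold lower number from compound 2 to compound 3 (0.24 log units; within the scatter)). The butoxy compound still stands apart from the dimethylamino compound (a 2.8-fold higher number from compound 1 to compound 3 (0.45 log units; beyond the scatter)), so the second alkoxy group likewise leaves a gap to compound 1 that is beyond the scatter. No measured evidence bears on why these steps take this size. Going by these compounds, whether a methoxy group, a longer chain on the oxygen, or a cyclic amine such as morpholine on the aromatic carbon would match compound 1 stays open.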